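Replacing the 2-bromophenyl group of compound 3

The compounds below may be only part of what the source reports. "The series", "measured", "known", "first", "only" and "open" are said of these compounds alone.

Going by the values given here, in a functional assay on HL-60 cells (Homo sapiens) for inhibition, read by MTT assay, with a stated time of 48 h, tested at 10 uM (on this read-out lower numbers stand for less inhibition of growth and higher numbers for more inhibition of growth at the one concentration tested), compound 3 (`Cc1oc2c([C@H]3CCN(C)C[C@H]3O)c(O)cc(O)c2c(=O)c1C(O)c1ccccc1Br`) reaches 52% and stands highest of the three compounds measured so far. Compound 1 (`Cc1cc(=O)c2c(O)cc(O)c([C@H]3CCN(C)C[C@H]3OC(=O)c3ccco3)c2o1`) gives 22% and compound 2 (`Cc1oc2c([C@H]3CCN(C)C[C@H]3O)c(O)cc(O)c2c(=O)c1C(O)c1ccc(Cl)cc1`) gives 2% in the same test, and both lie lower than compound 3 by more than the scatter.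

Compound 4 (`Cc1oc2c([C@H]3CCN(C)C[C@H]3O)c(O)cc(O)c2c(=O)c1C(O)c1csc([N+](=O)[O-])c1`) has not yet been measured. It carries 5-nitrothiophen-3-yl in place of 2-bromophenyl on a saturated chain carbon bound to an aromatic carbon and an oxygen on a saturated carbon and keeps the rest of compound 3 unchanged.

Among the compounds with values here, only one measured step bears on this place. With 2-bromophenyl in place of 4-chlorophenyl it gave a number 50 percentage points higher from compound 2 to compound 3 (beyond the scatter) and counts as large. So a swap at this place alone can move the number a long way, but no measured compound has a five-membered aromatic ring there. With compound 3 at 52% as the top of so small a set, a new group is expected to land lower rather than higher. The expected change is a sizeable drop, estimated as a number 25 percentage points lower from compound 3 to compound 4 (beyond the scatter) and uncertain in size. For compound 4 the estimate is 27% with an expected range of 5% to 58% in this test.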

Compound 4, percent growth inhibition at one concentration: 45%
Compound 4: the middle estimate sits 18 percentage points below what was measured; measured number inside the range.
By their numbers in this assay, from the lowest: compound 2; then compound 1; then compounds 4 and 3 (each within the scatter of the next).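

In this assay, the step with 5-nitrothiophen-3-yl in place of 2-bromophenyl reads as a number 7 percentage points lower from compound 3 to compound 4 (within the scatter) and so cannot separate the two groups. This place on the saturated chain carbon therefore accepts a five-membered aromatic ring with 1 hetero atom as well as a six-membered aromatic ring of carbon only, and a group with 3 hydrogen-bond acceptors as well as one with none. Set against 4-chlorophenyl, the new group gives a number 43 percentage points higher from compound 2 to compound 4 (beyond the scatter), so the large gap seen for compound 2 now recurs with a second, very different group, and compound 2 stands apart from both compound 3 and compound 4 (no measurement shown offers a reason for this:).

The compounds shown do not say what the nitro group contributes to compound 4, a question that thiophen-3-yl without it or with an amine in its place would address. Nor do they separate the chlorine of compound 2 from where it sits on the ring. Plain phenyl at this place would help to settle that.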